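A Small Extension on a Slowly Cleared Compound

The compounds below may be only part of what the source reports. "The series", "measured", "known", "first", "only" and "open" are said of these compounds alone.

In total, three compounds built on one shared core have been run in an ADME assay on microsomes from liver (Homo sapiens) for metabolic stability; on this read-out lower numbers stand for slow clearance and higher numbers for fast clearance. Compound 1, `COc1cc(C(=O)N2CCCC2)ccc1-c1ccnc2[nH]c(C3CCOCC3)cc12`, gives 74 uL/min in this assay. Compound 2, `CN(C)C(=O)CN1CCC(c2cc3c(-c4ccc(=O)n(C)c4)ccnc3[nH]2)CC1`, gives < 3 uL/min in this assay, and this is a limit of the assay rather than a number. Compound 3, `CC(=O)N1CCC(c2cc3c(-c4ccc(=O)n(C(C)C)c4)ccnc3[nH]2)CC1`, gives < 3 uL/min in this assay, again a limit rather than a number. Compound 2 therefore stands at the low end of what has been seen, at the limit of < 3 uL/min in this assay, at which 2 of the 3 values shown sit; compound 1 is the only one of the three for which the assay returned a number.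

The step followed here leads from compound 2 to compound 4, `CCn1cc(-c2ccnc3[nH]c(C4CCN(CC(=O)N(C)C)CC4)cc23)ccc1=O`, which differs from compound 2 in a single place: methyl in place of hydrogen on a saturated chain carbon bound to an aromatic nitrogen. Among the measured compounds shown here, no step between two measured compounds is available to guide the expectation, and compound 2 itself sits at a limit, so any further slowing of clearance could not be seen. The expected step from compound 2 to compound 4 is a number no lower from compound 2 to compound 4 (the limit leaves the size open), which is none beyond the usual scatter. Compound 4 is accordingly estimated at 3 uL/min in this assay, within a range from 1 uL/min to 8 uL/min, with a real chance that the assay once more reports only a limit.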

Compound 4, intrinsic clearance in a liver preparation (reported as CLH), per the amount of preparation that the assay uses: < 3 uL/min
Compound 4: a limit, no number; the forecaster's own chance of this, stated with the estimate: 60%; the middle value sits exactly at the limit.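

Among the compounds shown here, compound 2 and compound 4 both end at a limit of this assay rather than at a number, and no step between them can be read. The compounds shown leave open how slow the clearance of each of these two compounds really is, and whether going from methyl to ethyl changes it at all.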